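Methyl for methoxy on a rearranged indolocarbazole-type core

The source may hold more compounds than are shown below. What is called first, only, known or untested is meant among the compounds shown, and "the series" means these compounds.

Compound 1, `COc1ccc2[nH]c3c4cn[nH]c4c4c(c3c2c1)C(=O)NC4=O`: in a functional assay on A549 cells (Homo sapiens) for cytotoxicity, read by MTT assay, with a stated time of 72 h (on this read-out lower numbers stand for stronger inhibition and higher numbers for weaker inhibition), compound 1 gives > 100000 nM, which is a limit of the assay and not a number.
Compound 2, `Cc1ccc2[nH]c3c4cn[nH]c4c4c(c3c2c1)C(=O)NC4=O`: in this assay compound 2 gives > 100000 nM, again a limit of the assay.
Compound 3, `COc1ccc2[nH]c3c(c4c(c5ccnn53)C(=O)NC4=O)c2c1`: in this assay compound 3 gives 8000 nM.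

Compound 3 and compound 1 are built from the same atoms joined differently; the difference between the two cores is not broken down here. The change from compound 1 to compound 2 is methyl in place of methoxy on an aromatic carbon, and its step that the two limits leave unreadable from compound 1 to compound 2 cannot be read because both values sit at the limit of > 100000 nM in this assay, at which 2 of the 3 values shown sit.

Compound 4, `Cc1ccc2[nH]c3c(c4c(c5ccnn53)C(=O)NC4=O)c2c1`, has not been measured. It differs from compound 3 by methyl in place of methoxy on an aromatic carbon, the same change as that from compound 1 to compound 2. The measured pair gives no readable guide to its size, so the expectation rests on compound 3 and its value 8000 nM. The step of a 1.3-fold higher number from compound 3 to compound 4 (0.10 log units; within the scatter) is expected to be small. For compound 4 in this assay a value of about 10000 nM is estimated, between 3000 nM and 40000 nM.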

Compound 4, half-maximal inhibitory concentration: 8000 nM
Compound 4: the middle estimate sits 1.3-fold (0.10 log units) above what was measured, within the range that was stated.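

In this assay, methyl in place of methoxy on an aromatic carbon of the core that gives numbers gives no change at the digits printed from compound 3 to compound 4 (within the scatter). On the core of compound 1 the same change cannot be read, because compound 1 and compound 2 both stand at a limit of the assay and not at a number: the limit of > 100000 nM in this assay, at which 2 of the 4 values shown sit. Among these compounds, the change has therefore been read on one core only, so the data show neither that its outcome carries from one core to the other nor that it fails to, and the single readable step is no pattern for the series.

The compounds shown carry only methoxy and methyl at this carbon, so it stays open how an amine, a carboxylic acid or a longer chain there would read on either core. On these data alone, it also stays open whether any such group would bring the core of compound 1 to a readable number in this assay.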